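The source may hold more compounds than are shown below. What is called first, only, known or untested is meant among the compounds shown, and "the series" means these compounds.

Among the measured compounds shown here, compound 1 `O=C(CN1CCN(c2nnc(Cc3ccncc3)c3ccccc23)CC1)Nc1cccc(Br)c1` is the only compound of this set with a single number: in a functional assay on A549 cells (Homo sapiens) for cytotoxicity, read by MTT assay, with a stated time of 72 h (a lower number here means a stronger inhibitor, a higher number a weaker inhibitor), compound 1 gives 1530 nM. Compound 2 `Cc1ccccc1NC(=O)CN1CCN(c2nnc(Cc3ccccc3)c3ccccc23)CC1` differs from compound 1 in two places; in this assay compound 2 is reported as "not active" (no number reported), and no count of the two differences is given, so nothing further can be drawn from that pair. Compound 3 `Cc1cccc(Cl)c1NC(=O)CN1CCN(c2nnc(Cc3ccncc3)c3ccccc23)CC1` has not yet been measured. It differs from compound 1 in one place: 2-chloro-6-methylphenyl in place of 3-bromophenyl on an amide-type nitrogen. For the measured compounds named here, no measured step of this kind is known here, so the expected change is a 2.0-fold higher number from compound 1 to compound 3 (0.29 log units; within the scatter), a small weakening that may not exceed the scatter. Compound 3 is therefore expected to give about 3000 nM, within 1000 nM to 15000 nM.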

Compound 3, half-maximal inhibitory concentration: 7190 nM
The estimate for compound 3 lay 2.4-fold (0.38 log units) below the measured number; the range from low to high includes it.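

In this assay, putting 2-chloro-6-methylphenyl in place of 3-bromophenyl on the amide-type nitrogen gives a 4.7-fold higher number from compound 1 to compound 3 (0.67 log units; beyond the scatter) and so weakens the compound beyond the usual scatter. This first readable step shows that the group at this position can alter the measured cytotoxicity, though it rests on this single pair. No measurement shown here accounts for the loss. Still open, going by these compounds, is how plain phenyl or 3-chlorophenyl would behave on this nitrogen. Either could help separate the effect of the halogen from that of the methyl.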